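The source may hold more compounds than are shown below. What is called first, only, known or untested is meant among the compounds shown, and "the series" means these compounds.

In an ADME assay on RAW264.7 cells (Mus musculus) for cytotoxicity, read by MTT assay, with a stated time of 48 h (a lower number here means that less compound is tolerated, a higher number that more compound is tolerated), compound 2 `C#CCOc1ccc(-c2noc(N(CC#C)C3CCCCC3)n2)cc1` stands highest of the three compounds measured, giving 101 ug/mL. Its nearest neighbour is compound 3 `C#CCN(c1nc(-c2ccc(OC)cc2)no1)C1CCCCC1`, which gives 28 ug/mL, and the furthest is compound 1 `C#Cc1ccc(-c2noc(NC3CCCCC3)n2)cc1`, which gives 19.8 ug/mL.

Compound 4 `C#CCOc1ccc(-c2noc(NC3CCCCC3)n2)cc1` is not yet measured. It differs from compound 2 in one place: hydrogen in place of propargyl on a nitrogen on an aromatic ring. Among the measured compounds shown here, the single measured step that bears on this change is the removal of the other propargyl group of compound 2, on its ether oxygen, which gave a 3.6-fold lower number from compound 2 to compound 3 (0.56 log units; beyond the scatter). Compound 1, which like compound 4 carries a hydrogen on the ring nitrogen but lacks the ether, shows a lower number than compound 2 as well, though the two differ in more than one place.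

Taken together, these point to a modest downward step in this assay. Compound 4 is therefore expected to come out at 40 ug/mL, within a range of 18 ug/mL to 90 ug/mL, which means an estimated step of a 2.5-fold lower number from compound 2 to compound 4 (0.40 log units; beyond the scatter).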

Compound 4, half-maximal cytotoxic concentration: 38.3 ug/mL
The estimate for compound 4 lay 1.0-fold (0.02 log units) above the measured number; the measured number falls inside the stated range.
By their numbers in this assay, from the lowest: compounds 1, 3 and 4 (each within the scatter of the next); then compound 2.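

In this assay, among the compounds shown here, hydrogen in place of propargyl on the nitrogen on the aromatic ring gives a 2.6-fold lower number from compound 2 to compound 4 (0.42 log units; beyond the scatter), the first measured step at this position. It is a modest step beyond the scatter, as is the one at the ether oxygen, a 3.6-fold lower number from compound 2 to compound 3 (0.56 log units; beyond the scatter), so removing propargyl from either place gives a lower number. With hydrogen on that nitrogen, propargyloxy in place of ethynyl on an aromatic carbon gives a 1.9-fold higher number from compound 1 to compound 4 (0.29 log units; within the scatter), so those two compounds cannot be told apart in this assay. Nothing available explains these numbers.

From the compounds shown here alone, it remains open whether a methyl group or a longer chain on that nitrogen would give a number closer to that of compound 2. The same question stands for an amine or a carboxylic acid on the chain at the ether oxygen.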